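Trading a Methoxyphenyl for a Fluorophenyl: What to Expect

This account rests on a few compounds, and the source may have more. Where it says the series, first, only, none or still open, it means among the compounds named here.

In a functional assay on the whole organism with Mus musculus as the target (a lower number here means that less compound is needed, a higher number that more compound is needed for the effect), compound 2 `COc1cccc(Oc2ncccc2C(=O)NCc2ccccc2)c1` gives 0.01 mg/kg, the lowest of the two numbers; its nearest neighbour, compound 1 `N#Cc1cccc(Oc2ncccc2C(=O)NCc2ccccc2)c1`, gives 0.1 mg/kg. Among the measured compounds shown here, the single measured step, a 10-fold lower number from compound 1 to compound 2 (1.00 log units; beyond the scatter), shows that the group carried on that ring matters. Compound 3 `O=C(NCc1ccccc1)c1cccnc1Oc1ccccc1F` differs from compound 2 by 2-fluorophenyl in place of 3-methoxyphenyl on an oxygen on an aromatic ring. For the measured compounds named here, no measured step covers this exchange, so the direction is uncertain; a modest rise is expected, a 3.0-fold higher number from compound 2 to compound 3 (0.48 log units; beyond the scatter), because a 10-fold lower number from compound 1 to compound 2 (1.00 log units; beyond the scatter) accompanied the arrival of the methoxy group that compound 3 lacks. Compound 3 is therefore estimated at 0.03 mg/kg, with a range from 0.005 mg/kg to 0.2 mg/kg.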

Compound 3, minimum effective dose: 0.01 mg/kg
Estimate against measurement, compound 3: 3.0-fold (0.48 log units) above; the measured number falls inside the stated range.
By their numbers in this assay, from the lowest: compounds 2 and 3 (each within the scatter of the next); then compound 1.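

In this assay the exchange of 3-methoxyphenyl for 2-fluorophenyl on this oxygen gives no change at the digits printed from compound 2 to compound 3 (within the scatter) and so leaves the number where it was. The methoxy group is therefore not required for a number this low, since a ring carrying fluorine instead serves equally well here. Set against the nitrile, the same 2-fluorophenyl gives a 10-fold lower number from compound 1 to compound 3 (1.00 log units; beyond the scatter) and thus matches the step seen with methoxy, leaving compound 1 alone at the higher number.

On these data alone, whether an amine or a carboxylic acid on this ring would hold the number remains open. No measurement shown here accounts for any of these steps.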